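The source may hold more compounds than are shown below. What is called first, only, known or untested is meant among the compounds shown, and "the series" means these compounds.

Compound 1 `COC(=O)c1c(-c2ccc([N+](=O)[O-])cc2)oc2cc(OC)ccc2c1=O` carries a nitro group on an aromatic carbon. In a functional assay on HT-29 cells (Homo sapiens) for cytotoxicity, read by MTT assay, with a stated time of 6 days (on this read-out lower numbers stand for an effect already at smaller amounts and higher numbers for an effect only at larger amounts of compound), compound 1 gives only a limit of the assay, > 25 ug/mL. Compound 2 `COC(=O)c1c(-c2ccc(O)cc2)oc2cc(OC)ccc2c1=O` differs from compound 1 in one place: hydroxy in place of nitro on an aromatic carbon. In this assay compound 2 gives 19.2 ug/mL. This change produced an at least 1.3-fold lower number from compound 1 to compound 2 (0.11 log units; that floor lies within the scatter). Its true size cannot be pinned down further because the value of compound 1 is the limit of > 25 ug/mL in this assay, at which 2 of the 3 values shown sit.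

Compound 3 `COc1ccc2oc(-c3ccc([N+](=O)[O-])cc3)c(C(=O)O)c(=O)c2c1` has a different core; the difference between the cores of compound 1 and compound 3 is not broken down here. In this assay compound 3 gives only a limit of the assay, > 25 ug/mL.

Compound 4 `COc1ccc2oc(-c3ccc(O)cc3)c(C(=O)O)c(=O)c2c1` has not yet been measured. It differs from compound 3 in one place: hydroxy in place of nitro on an aromatic carbon. For the measured compounds named here, this is the same change, at the same kind of position, as the one separating compound 1 from compound 2. Since compound 3 already sits at a limit, and the earlier change gave only a floor that lies within the usual scatter, a small movement at most is expected. In this assay the expected step is a step that the limit leaves unreadable from compound 3 to compound 4; this expectation rests on the measured step of an at least 1.3-fold lower number from compound 1 to compound 2 (0.11 log units; that floor lies within the scatter).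

Compound 4 is therefore expected to give in this assay roughly 28 ug/mL, estimated to fall between 12 ug/mL and 60 ug/mL, with a real chance that the assay again reports only a limit.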

Compound 4, concentration for half-maximal effect: > 25 ug/mL
Compound 4: no number, only a limit (the forecaster's own chance of this, stated with the estimate: 60%); the middle value lies beyond the limit too.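

In this assay compound 3 and compound 4 both give only a limit, so the step between them, hydroxy in place of nitro, cannot be read: the limit of > 25 ug/mL in this assay, at which 3 of the 4 values shown sit.

The compounds shown leave open whether this change moves the number at all on the core of compound 3, and whether it does so beyond the usual scatter on the core of compound 1.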